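Amide nitrogen exchange from compound 2 to compound 4

A few compounds are considered here, and "the series" means these few. Any claim that something is new, unique, unknown or untested is made for them only; others in the source may bear on it.

In a physicochemical assay for lipophilicity, at pH 7.4 (on this read-out lower numbers stand for lower lipophilicity and higher numbers for higher lipophilicity), compound 2 (`O=C1Cc2cc(NC(=O)[C@H]3CCCN3C(=O)C3(c4cccc(Cl)c4)CCCC3)ccc2N1`) gives 5. Compound 3 (`O=C(Nc1ccc2[nH]ncc2n1)[C@H]1CCCN1C(=O)C1(c2ccc(Cl)cc2)CCC1`) gives 4.7, within the scatter of compound 2, while compound 1 (`COc1ccc(C2(C(=O)N3CCC[C@@H]3C(=O)Nc3ccc4[nH]ncc4n3)CCC2)cc1`) gives 3.9, which sits under compound 2 by a gap that lies beyond the scatter. Compound 4 (`O=C(Nc1ccc(O)cc1)[C@H]1CCCN1C(=O)C1(c2cccc(Cl)c2)CCCC1`) differs from compound 2 by a group of 7 heavy atoms (6 carbon, 1 oxygen; one six-membered aromatic ring of carbon only) in place of a group of 10 heavy atoms (8 carbon, 1 nitrogen, 1 oxygen; one five-membered non-aromatic ring with 1 hetero atom, one six-membered aromatic ring of carbon only), on an amide-type nitrogen, with 4-hydroxyphenyl as the entering group. Among the measured compounds shown here, the one measured step, a number 0.80 log units higher from compound 1 to compound 3 (beyond the scatter), is modest but is chloro in place of methoxy on an aromatic carbon, so it does not bear on this exchange. The expectation therefore rests on compound 2 at 5 alone. The expected step in this assay is no change at the digits printed from compound 2 to compound 4 (within the scatter), none beyond the scatter. Compound 4 is estimated at 5, with an expected range of 4.5 to 5.5.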

Compound 4, distribution coefficient: 5.5
Beside the measured number, compound 4's estimate is 0.50 log units below it, within the range that was stated.
By their numbers in this assay, from the lowest: compound 1; then compounds 3 and 2 (each within the scatter of the next); then compound 4.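

In this assay the exchange on the amide-type nitrogen reads as a number 0.50 log units higher from compound 2 to compound 4 (beyond the scatter) and is the first step shown at this place. The number rises although 4-hydroxyphenyl has fewer heavy atoms than the group that leaves, while both groups have the same hydrogen-bond donor and acceptor counts. No measurement shown accounts for this step.

Still open, from the compounds shown here alone, is how 4-aminophenyl or a group carrying a carboxylic acid would read on this nitrogen. Also open, going by these compounds, is whether the step carries over to the core of compound 3.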